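The source may hold more compounds than are shown below. What is called first, only, known or untested is meant among the compounds shown, and "the series" means these compounds.

Working notes on the series. Within the data shown here, in a functional assay on SK-BR-3 cells (Homo sapiens) for antiproliferative activity, with a stated time of 72 h (on this read-out lower numbers stand for stronger inhibition of growth and higher numbers for weaker inhibition of growth), compound 2 `Cc1ccc(CN(C)C(=O)c2cc(Cl)c(O)cc2O)cc1` gives 7200 nM, the only number so far. Compound 1 `O=C(NCc1ccccc1)c1cc(Cl)c(O)cc1O` is recorded in this assay as "not active" (no number reported), without a number, so compound 2 has no numerical comparator.

Compound 3 `Cc1ccccc1CN(C)C(=O)c1cc(Cl)c(O)cc1O` has yet to be measured. It has the same atoms as compound 2, joined differently: 2-methylphenyl in place of 4-methylphenyl on a saturated chain carbon bound to an amide-type nitrogen, with 2-methylphenyl in place of 4-methylphenyl on a saturated chain carbon bound to an amide-type nitrogen.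

Among the measured compounds shown here, no pair of measured compounds isolates this kind of change, so the expectation rests only on compound 2 at 7200 nM. A small loss of growth inhibition in this assay is expected, close to the usual scatter, and the estimated step is a 1.3-fold higher number from compound 2 to compound 3 (0.10 log units; within the scatter). For compound 3 the expected value is 9000 nM, with an estimated range of 3000 nM to 27000 nM.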

Compound 3, concentration for 50% growth inhibition: 4200 nM
Estimate against measurement, compound 3: 2.1-fold (0.33 log units) above; measured number inside the range.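

In this assay, 2-methylphenyl in place of 4-methylphenyl on a saturated chain carbon bound to an amide-type nitrogen gives a 1.7-fold lower number from compound 2 to compound 3 (0.23 log units; within the scatter). Among these compounds, this is the first pair with a number on both sides, and it shows that this exchange between two groups with the same atoms leaves the read-out within the scatter, so compound 2 and compound 3 cannot be ordered. Nothing measured here bears on this result.

Open, as far as these compounds go, is whether an amine or a carboxylic acid carried on the aromatic ring in place of the methyl group would give a step beyond the scatter in this assay. Also open, from the compounds shown here alone, is how a longer chain at this place would read out.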